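Lengthening one ether chain from compound 2

A few compounds are considered here, and "the series" means these few. Any claim that something is new, unique, unknown or untested is made for them only; others in the source may bear on it.

In a functional assay on A549 cells (Homo sapiens) for inhibition, read by colorimetric assay and MTT assay, with a stated time of 72 h (on this read-out lower numbers stand for stronger inhibition and higher numbers for weaker inhibition), compound 2 (`COc1ccccc1-c1cnc(OC)n1C`) gives > 100000 nM, which is a limit of the assay and not a number. For the measured compounds named here, compound 1 (`C=CCCCCOc1ccccc1-c1cnc(OCCC=C)n1C`) is the only compound so far with a measured number, at 9000 nM.

Compound 3 (`C=CCCCCOc1ccccc1-c1cnc(OC)n1C`) departs from compound 2 at one place: pent-4-en-1-yl in place of hydrogen on a saturated chain carbon bound to an oxygen on an aromatic ring. Put another way, methoxy gives way to (hex-5-en-1-yl)oxy, while the second methoxy stays.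

Going by the values given here, no measured step isolates this change, and a limit cannot fix the size of any step from compound 2. Even so, a step towards stronger inhibition, beyond the scatter, is expected in this assay, since compound 1 carries the same hex-5-en-1-yl group and gives 9000 nM. The expected step is an at least 3.3-fold lower number from compound 2 to compound 3 (0.52 log units; beyond the scatter). For compound 3 the estimated value is 30000 nM, with an expected range of 10000 nM to 100000 nM.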

Compound 3, half-maximal inhibitory concentration: 80000 nM
Estimate against measurement, compound 3: 2.7-fold (0.43 log units) below; low and high end bracket the measured number.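

Putting (hex-5-en-1-yl)oxy in place of methoxy, with the second methoxy kept, brings the compound within measurable range in this assay, yet this reads only as an at least 1.2-fold lower number from compound 2 to compound 3 (0.09 log units; that floor lies within the scatter). That step stays a floor because the value for compound 2 is a limit of the assay and not a number: the limit of > 100000 nM in this assay, at which 1 of the 3 values shown sits. The clearer result lies at the second ether: with hex-5-en-1-yl kept, exchanging allyl for hydrogen on the saturated chain carbon bound to an oxygen on an aromatic ring gives an 8.9-fold higher number from compound 1 to compound 3 (0.95 log units; beyond the scatter), so the longer second chain accompanies stronger inhibition in this one pair.

On these data alone, how the second chain behaves with the first methoxy kept remains open. Also open, as far as these compounds go, is whether a hexyl or propyl chain in place of hex-5-en-1-yl would hold the value of compound 3.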